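The source may hold more compounds than are shown below. What is called first, only, known or untested is meant among the compounds shown, and "the series" means these compounds.

In a functional assay on Jurkat cells (Homo sapiens) for cytotoxicity, read by MTT assay, with a stated time of 24 h (a lower number here means that less compound is needed, a higher number that more compound is needed for the effect), three compounds built on a shared core have been measured. Compound 3 `CCOC(=O)c1cc([Se]c2ccccc2)c2cc(OC)ccc2n1` gives 102000 nM. Compound 2 `CCOC(=O)c1cc([Se]c2ccccc2)c2cc(Cl)ccc2n1`, which carries the change (chloro in place of methoxy on an aromatic carbon), gives 53000 nM; the step of a 1.9-fold lower number from compound 3 to compound 2 (0.28 log units; within the scatter) is small, and the two numbers sit within the scatter of each other. Compound 1 `CCOC(=O)c1cc([Se]c2ccc3cc(OC)ccc3c2)c2cc(OC)ccc2n1` differs from compound 3 in a larger way; how the two cores differ is not broken down here. In this assay compound 1 gives 31300 nM, a number that lies within the scatter of that of compound 2 and beyond the scatter from that of compound 3.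

Compound 4 `CCOC(=O)c1cc([Se]c2ccc3cc(OC)ccc3c2)c2cc(Cl)ccc2n1` has not yet been measured. It differs from compound 1 by chloro in place of methoxy on an aromatic carbon, and the surroundings of the place are the same as for the change from compound 3 to compound 2, so this is the same change applied to the core of compound 1. Among the measured compounds shown here, that earlier step, a 1.9-fold lower number from compound 3 to compound 2 (0.28 log units; within the scatter), is the only guide to its effect, and it was small. For the measured compounds named here, on that basis the step from compound 1 to compound 4 is expected to be of about the same size, a 1.8-fold lower number from compound 1 to compound 4 (0.27 log units; within the scatter), since the single measured instance of the change gave a 1.9-fold lower number from compound 3 to compound 2 (0.28 log units; within the scatter). Compound 4 is therefore estimated at 17000 nM, with a plausible range from 7000 nM to 40000 nM.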

Compound 4, half-maximal effective concentration: 29200 nM
For compound 4 the middle estimate is 1.7-fold (0.23 log units) below the measured one, and the stated range covers the measured number.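

In this assay, chloro in place of methoxy on the core of compound 1 gives a 1.1-fold lower number from compound 1 to compound 4 (0.03 log units; within the scatter), so compound 1 and compound 4 cannot be told apart in this read-out. Set beside the earlier instance of the same change, the new step agrees with it as far as these data can tell: the same change on two cores in this assay, a 1.9-fold lower number (0.28 log units; within the scatter) from compound 3 to compound 2 and a 1.1-fold lower number (0.03 log units; within the scatter) from compound 1 to compound 4, 1.8-fold (0.25 log units) apart, within the scatter of two such steps. Among the compounds shown here, this shows that the change carried from one core to the other without a step beyond the scatter on either core, but it does not show that the change has a real effect on either core, or that its effect is the same on both, as each step and the gap between them lie within the scatter and only two cores are represented.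

The compounds shown leave open what a group other than methoxy or chloro would do at this place on the shared core, for example an amine or a nitrile. They also leave open whether the picture holds when the ethyl ester gives way to a carboxylic acid or an amide, or on a third core.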